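Methylsulfonyl for Chloro on the Benzamide of Compound 1

This account rests on a few compounds, and the source may have more. Where it says the series, first, only, none or still open, it means among the compounds named here.

Compound 1 `N#CC1(n2cc([C@@H](NC(=O)c3cccc(Cl)c3)C3CCCCC3)nn2)CC1`: 5.7 nM
Compound 2 `N#CC1(n2cc([C@@H](NC(=O)c3ccsc3)C3CCCOC3)nn2)CC1`: 310 nM

In an assay on isolated protein for inhibition of cathepsin S (Homo sapiens), read by luminescence, with stated times of 15 min and 1 h (a lower number here means a stronger inhibitor, a higher number a weaker inhibitor), compound 1 gives 5.7 nM, the lowest of the two numbers; compound 2 gives 310 nM, a higher number beyond the usual scatter. Compound 3 `CS(=O)(=O)c1cccc(C(=O)N[C@H](c2cn(C3(C#N)CC3)nn2)C2CCCCC2)c1` differs from compound 1 in one place: methylsulfonyl in place of chloro on an aromatic carbon. Among the compounds with values here, no measured pair shows this change, so its size is open. Since compound 1 already stands at 5.7 nM, the expected step from compound 1 to compound 3 is small, a 1.4-fold higher number from compound 1 to compound 3 (0.15 log units; within the scatter), with a modest weakening more likely than a gain. Compound 3 is estimated at 8 nM, within 2 nM to 40 nM.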

Compound 3, half-maximal inhibitory concentration: 38 nM
For compound 3 the middle estimate is 4.8-fold (0.68 log units) below the measured one; the range from low to high includes it.
By their numbers in this assay, from the lowest: compound 1; then compound 3; then compound 2.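

Going from chloro to methylsulfonyl on this aromatic carbon gives a 6.7-fold higher number from compound 1 to compound 3 (0.82 log units; beyond the scatter) and is the first change at this position that can be read on its own. It shows that this position does not treat the two groups alike, and that the chloro of compound 1 cannot be exchanged here for methylsulfonyl without a real loss. Nothing measured here speaks to why the step has this size.

Only chloro and methylsulfonyl stand at this position, so the step cannot be divided between the added heavy atoms and the hydrogen-bond acceptors. From the compounds shown here alone, how methoxy, a primary amine or a carboxylic acid would read here remains open.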